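The compounds below may be only part of what the source reports. "The series", "measured", "known", "first", "only" and "open" are said of these compounds alone.

Compounds measured in an assay on CHO cells for displacement of a labelled ligand from adenosine receptor A3 (Homo sapiens), read by scintillation counting, tested at 10 uM; a higher number here means more inhibition at the concentration tested (going by the name of the read-out), a lower number less inhibition: compound 1 `CC(C)(C)Cc1csc(N)c1C(=O)c1ccc(Cl)c(Cl)c1` gives 10%; compound 2 `CC(C)(C)Cc1c(Br)sc(N)c1C(=O)c1ccc(Cl)cc1` gives 1%; compound 3 `CC(C)(C)Cc1c(Br)sc(N)c1C(=O)c1cccc(Cl)c1` gives 1%.

Compound 3 stands level with compound 2 at the digits shown, and the two together are the lowest of the three values; compound 1 is higher by a difference that lies within the scatter. Going by the values given here, the only single-place step measured, no change at the digits printed from compound 2 to compound 3 (within the scatter), shows no change. Compound 4 `CC(C)(C)Cc1c(Br)sc(N)c1C(=O)c1ccc(Cl)c(Cl)c1` differs from compound 3 by chloro in place of hydrogen on an aromatic carbon. Among the compounds with values here, no measured step adds a chloro group in this way. Compound 1 already carries the same two chloro groups on a core without the bromo group and gives only 10%. The step is therefore expected to stay within the scatter, a number 4 percentage points higher from compound 3 to compound 4 (within the scatter). Compound 4 is estimated at 5%, in the range -8% to 20%.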

Compound 4, a percentage reported as inhibition, at one concentration (the size of the read-out at that concentration, not a potency): 1%
For compound 4 the middle estimate is 4 percentage points above the measured one, and the stated range covers the measured number.
By their numbers in this assay, from the lowest: compounds 2, 3, 4 and 1 (each within the scatter of the next).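

In this assay, chloro in place of hydrogen on the aromatic carbon ortho to a chloro group and para to a large group shows no change at the digits printed from compound 3 to compound 4 (within the scatter) and, starting from the 4-chlorophenyl group, no change at the digits printed from compound 2 to compound 4 (within the scatter) in this series. Bromo in place of hydrogen on the shared core, a change no earlier step covered, shows a number 9 percentage points lower from compound 1 to compound 4 (within the scatter) in this first bromo comparison. No evidence on this result is available.

Open, going by these compounds, is whether a methoxy group or an amine at this place would give a different number in this assay on this core.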